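Aryl replacement on the chain carbon: compound 3 to compound 4

This account rests on a few compounds, and the source may have more. Where it says the series, first, only, none or still open, it means among the compounds named here.

Measured so far:
- compound 1 `CCCSc1nc(N/N=C(\C)c2ccccc2O)c2nnn(Cc3ccc(Cl)cc3)c2n1` gives 11200 nM
- compound 2 `CCCSc1nc(N/N=C(\C)c2ccccc2O)c2nnn(Cc3ccccc3Cl)c2n1` gives a limit of the assay, > 64000 nM
- compound 3 `CCCSc1nc(N/N=C(\C)c2ccccc2O)c2nnn(Cc3cccc(Cl)c3)c2n1` gives 13000 nM

All three were read in a functional assay on ECa-109 cells (Homo sapiens) for antiproliferative activity, read by MTT assay, with a stated time of 72 h; a higher number here means a weaker inhibitor, a lower number a stronger inhibitor. Compound 3 holds the higher of the two numbers; compound 1 is nearest, the gap being a 1.2-fold higher number from compound 1 to compound 3 (0.06 log units; within the scatter), within the scatter. The remaining value belongs to compound 2 and is only a limit, (the limit of > 64000 nM in this assay, at which 1 of the 3 values shown sits).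

Compound 4 `CCCSc1nc(N/N=C(\C)c2ccccc2O)c2nnn(Cc3ccco3)c2n1` differs from compound 3 at one place: furan-2-yl in place of 3-chlorophenyl on a saturated chain carbon bound to an aromatic nitrogen.

Every measured step changes the same ring in the same place, so each bears on this one. a 1.2-fold higher number from compound 1 to compound 3 (0.06 log units; within the scatter) is within the scatter, while an at least 5.7-fold higher number from compound 1 to compound 2 (0.75 log units; beyond the scatter) and an at least 4.9-fold lower number from compound 2 to compound 3 (0.69 log units; beyond the scatter) are beyond it; the ring at this position can leave the number unchanged or push it to the limit. None of these steps brings in furan-2-yl, so the direction for compound 4 is open. For compound 4 the expected step is a 1.2-fold higher number from compound 3 to compound 4 (0.09 log units; within the scatter), a small one, with wide uncertainty. Compound 4 is estimated at 16000 nM in this assay, between 4500 nM and 60000 nM.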

Compound 4, half-maximal inhibitory concentration: 5760 nM
For compound 4 the middle estimate is 2.8-fold (0.44 log units) above the measured one; the measured number falls inside the stated range.
By their numbers in this assay, from the lowest: compounds 4, 1 and 3 (each within the scatter of the next, the first and the last beyond it). At a limit, above all of these: compound 2.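

In this assay, the chain carbon accepts a ring other than a chlorophenyl: furan-2-yl in place of 3-chlorophenyl gives a 2.3-fold lower number from compound 3 to compound 4 (0.35 log units; beyond the scatter), whereas furan-2-yl in place of 4-chlorophenyl gives a 1.9-fold lower number from compound 1 to compound 4 (0.29 log units; within the scatter). Swapping the six-membered ring for a five-membered aromatic ring with 1 hetero atom therefore costs nothing in this series, and the furan-2-yl separates from only one of those two chlorophenyl compounds. Compound 2 is held at a limit and not a number, so an at least 11-fold lower number from compound 2 to compound 4 (1.04 log units; beyond the scatter) is a bound only: the limit of > 64000 nM in this assay, at which 1 of the 4 values shown sits.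

As far as these compounds go, how an unsubstituted phenyl or a thiophen-2-yl would read at this place remains open, and with it whether the step follows the oxygen, the ring size or the loss of chlorine. The compounds shown vary only this one ring and are read on one cell line.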